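The source may hold more compounds than are shown below. What is called first, only, known or untested is meant among the compounds shown, and "the series" means these compounds.

Of the compounds shown here, three sharing one core have been measured in a functional assay on L1210 cells (Mus musculus), with a stated time of 1 days; a higher number here means a more potent compound, by a factor of ten per unit of this negative logarithm, a lower number a less potent compound. Compound 1 `CC1=C(N2CC2)C(=O)C(CC(C)OC(N)=O)=C(N2CC2)C1=O` gives 5.18. Compound 2 `CC1=C(N2CC2)C(=O)C(CCC(=O)N(C)C)=C(N2CC2)C1=O` gives 4.84, and compound 3 `CCC(OC)C1=C(N2CC2)C(=O)C(C)=C(N2CC2)C1=O` gives 4.84. Compound 3 therefore stands level with compound 2, the two together at the lowest of the three numbers, while compound 1 sits higher: a number 0.34 log units lower from compound 1 to compound 3 (beyond the scatter). The parallel step a number 0.34 log units lower from compound 1 to compound 2 (beyond the scatter) has the same size, and no change at the digits printed from compound 2 to compound 3 (within the scatter).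

Compound 4 `COC(CO)C1=C(N2CC2)C(=O)C(C)=C(N2CC2)C1=O` has not yet been measured. It differs from compound 3 in one place: hydroxy in place of methyl on a saturated chain carbon, two bonds along the chain from a double-bonded ring carbon and an oxygen on a saturated carbon. Going by the values given here, no measured step touches this place. The two steps that lie beyond the scatter, a number 0.34 log units lower from compound 1 to compound 2 (beyond the scatter) and a number 0.34 log units lower from compound 1 to compound 3 (beyond the scatter), each amount to a modest shift, and the exchange that leads to compound 4 is smaller than either of those, so a shift of at most that order is expected here, with no clear direction indicated by the three numbers in hand. The step expected is a number 0.11 log units higher from compound 3 to compound 4 (within the scatter), which lies within the scatter. Compound 4 is accordingly estimated at 4.95, with a range from 4.55 to 5.35.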

Compound 4, logarithm of the reciprocal of the active concentration, log(1/C): 5.27
For compound 4 the middle estimate is 0.32 log units below the measured one; low and high end bracket the measured number.
By their numbers in this assay, from the lowest: compounds 2 and 3 (each within the scatter of the next); then compounds 1 and 4 (each within the scatter of the next).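

Going by these compounds alone, the step of a number 0.43 log units higher from compound 3 to compound 4 (beyond the scatter) is the first reading at this place in this assay, and it shows that hydroxy in place of methyl on this saturated chain carbon, a change of ethyl to hydroxymethyl with the rest of the 1-methoxypropyl group kept, is enough to move the number beyond the scatter. Compounds 2 and 3 could not be told apart, yet the step of a number 0.43 log units higher from compound 2 to compound 4 (beyond the scatter) separates compound 4 from compound 2 by the same amount, while the step of a number 0.09 log units higher from compound 1 to compound 4 (within the scatter) shows that 2-hydroxy-1-methoxyethyl and the carbamate-bearing chain of compound 1 cannot be told apart in this assay. No accompanying evidence bears on this result, so the numbers describe the step without accounting for it.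

Going by these compounds, whether an amine or a carboxylic acid on this same chain carbon would give a number like that of hydroxy remains open, as does the effect of a longer chain ending in hydroxy. On these data alone, it is also open whether replacing methoxy with ethoxy in 2-hydroxy-1-methoxyethyl would leave the number unchanged in this assay and whether a step of this size recurs on other side chains.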